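Two stereocentres inverted on the saturated ring of compound 2

The source may hold more compounds than are shown below. What is called first, only, known or untested is meant among the compounds shown, and "the series" means these compounds.

Compound 1 `O=C1/C(=C2/C(=O)N([C@@H]3O[C@H](CO)[C@@H](O)[C@H](O)[C@H]3O)c3ccccc32)Nc2ccccc21` and compound 2 `O=C1/C(=C2/C(=O)N([C@@H]3O[C@H](CO)[C@@H](O)[C@H](O)[C@@H]3O)c3ccccc32)Nc2ccccc21` share every atom and bond and differ only in the drawn configuration at one saturated ring carbon. In a functional assay on KYSE-70 cells (Homo sapiens) for antiproliferative activity, read by crystal violet staining, with a stated time of 96 h (a lower number here means a stronger inhibitor, a higher number a weaker inhibitor), compound 1 gives 28900 nM, while compound 2 gives 11800 nM, the lower of the two numbers, so that the step of a 2.4-fold lower number from compound 1 to compound 2 (0.39 log units; beyond the scatter) is modest but beyond the scatter. Among the compounds with values here, the only evidence on that step is the fact that compounds 1 and 2 differ only in the configuration as drawn. Compound 3 `O=C1/C(=C2/C(=O)N([C@@H]3O[C@H](CO)[C@H](O)[C@H](O)[C@H]3O)c3ccccc32)Nc2ccccc21` is not yet measured; relative to compound 2, (the two compounds have the same atoms and bonds and differ only in configuration as drawn: 2 of 6 stereo elements differ; a stereocentre at a saturated ring carbon is drawn S in compound 2 and R in compound 3; a stereocentre at a saturated ring carbon is drawn S in compound 2 and R in compound 3). Within the data shown here, the single measured step shows that inverting one such centre moves the number by a modest amount, so a step of similar size, in either direction, is expected here, with a 1.9-fold higher number from compound 2 to compound 3 (0.27 log units; within the scatter) as the estimate. Compound 3 is therefore expected to give 22000 nM in this assay, within a range from 8000 nM to 60000 nM.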

Compound 3, half-maximal inhibitory concentration: 41500 nM
The estimate for compound 3 lay 1.9-fold (0.28 log units) below the measured number; the range from low to high includes it.
By their numbers in this assay, from the lowest: compound 2; then compounds 1 and 3 (each within the scatter of the next).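

Not every inversion on this saturated ring counts equally: in this assay the single inversion that links compound 1 and compound 3 gives a 1.4-fold higher number from compound 1 to compound 3 (0.16 log units; within the scatter), whereas the single inversion in the earlier step was beyond the scatter. Inverting two centres gives a 3.5-fold higher number from compound 2 to compound 3 (0.55 log units; beyond the scatter), so compound 2 now holds the lowest number of the three, beyond the scatter of both others, while compound 1 and compound 3 cannot be told apart. The only evidence for the larger of these new steps is structural: the fact that compounds 2 and 3 differ only in the configuration as drawn

The compounds shown leave open whether the remaining ring centres respond in the same way when inverted. They also leave open how the number would move if an amine or a carboxylic acid took the place of a ring hydroxyl.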